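This account rests on a few compounds, and the source may have more. Where it says the series, first, only, none or still open, it means among the compounds named here.

Of the compounds shown here, three have so far been measured in a functional assay, read by spectrophotometry, with a stated time of 30 min; a higher number here means a weaker inhibitor, a lower number a stronger inhibitor. Compound 1 `Cc1nc2c3ccccc3ccc2c2nc3c(ccc4ccccc43)c(-c3ccccc3S)c12` gives 89 ug/mL, compound 2 `Cc1ccc(-c2c3ccc4ccccc4c3nc3c2c(C)nc2c4ccccc4ccc32)cc1` gives 123 ug/mL, and compound 3 `Cc1nc2c3ccccc3ccc2c2nc3c(ccc4ccccc43)c(C)c12` gives 129 ug/mL. Compound 2 stands second highest of the three numbers, and both of its steps to the others, a 1.4-fold higher number from compound 1 to compound 2 (0.14 log units; within the scatter) and a 1.0-fold higher number from compound 2 to compound 3 (0.02 log units; within the scatter), lie within the scatter. The move to compound 4 `Cc1nc2c3ccccc3ccc2c2nc3c(ccc4ccccc43)c(-c3ccccc3)c12` is hydrogen in place of methyl on an aromatic carbon. Among the measured compounds shown here, the steps that bear on it, a 1.0-fold higher number from compound 2 to compound 3 (0.02 log units; within the scatter) and a 1.4-fold higher number from compound 1 to compound 3 (0.16 log units; within the scatter), show that exchanging the whole 4-methylphenyl or 2-sulfanylphenyl for methyl left the number within the scatter, so for compound 4 the expected step in this assay is a 1.0-fold lower number from compound 2 to compound 4 (0.01 log units; within the scatter), none beyond the scatter. Compound 4 is therefore estimated at 120 ug/mL, between 60 ug/mL and 240 ug/mL.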

Compound 4, half-maximal inhibitory concentration: 164 ug/mL
The estimate for compound 4 lay 1.4-fold (0.14 log units) below the measured number; the range from low to high includes it.
By their numbers in this assay, from the lowest: compounds 1, 2, 3 and 4 (each within the scatter of the next).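

At this position of the shared core, this assay now includes a plain phenyl: 4-methylphenyl to phenyl gives a 1.3-fold higher number from compound 2 to compound 4 (0.12 log units; within the scatter), phenyl in place of methyl gives a 1.3-fold higher number from compound 3 to compound 4 (0.10 log units; within the scatter), and hydrogen in place of sulfanyl gives a 1.8-fold higher number from compound 1 to compound 4 (0.27 log units; within the scatter). The four groups on this aromatic carbon therefore cannot be told apart in this assay, and neither the methyl nor the sulfanyl on the phenyl separates its compound from compound 4. Nothing measured here offers an explanation for this. On these data alone, whether an amine or a carboxylic acid on the phenyl would also stay within the scatter remains open.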